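The source may report more compounds than this note shows. Statements on the series, on what has been measured and on what is new or still open speak of the compounds shown alone.

Series notes, measured in a functional assay on A-375 cells (Homo sapiens) for antiproliferative activity, read by MTT assay, with a stated time of 72 h; a lower number here means a stronger inhibitor, a higher number a weaker inhibitor:
- compound 1 `COc1ncc(-c2ccc3c(c2)NC(=O)CO3)cc1NS(=O)(=O)c1ccc(F)cc1`: 26300 nM
- compound 2 `O=C1COc2ccc(-c3cnc(Cl)c(NS(=O)(=O)c4ccc(F)cc4)c3)cc2N1`: > 40000 nM (a limit)
- compound 3 `CC(C)N1C(=O)COc2ccc(-c3cccc(NS(=O)(=O)c4ccc(F)cc4)c3)cc21`: > 40000 nM (a limit)

Compound 1 is the only one of the three with an actual number, and it is a weak one in this assay. The other two results are limits, not numbers: the limit of > 40000 nM in this assay, at which 2 of the 3 values shown sit.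

Next in the series is compound 4 `COc1ccc(N2C(=O)COc3ccc(-c4cnc(OC)c(NS(=O)(=O)c5ccc(F)cc5)c4)cc32)cc1`, which keeps the core of compound 1 and adds 4-methoxyphenyl in place of hydrogen on an amide-type nitrogen in a ring.

For the measured compounds named here, the only measured step, an at least 1.5-fold higher number from compound 1 to compound 2 (0.18 log units; that floor lies within the scatter), is chloro in place of methoxy on an aromatic carbon. It is a floor within the scatter and does not involve that nitrogen, so it gives no size for this change. Going by the values given here, no measured step tests this nitrogen directly.

The one firm constraint is that compound 1 gives 26300 nM. That leaves little room for a higher number before the limit is reached. Any step that can be read as a number is therefore expected mainly toward a lower value, with wide uncertainty. The expected step is a 2.9-fold lower number from compound 1 to compound 4 (0.47 log units; beyond the scatter).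

For compound 4 the estimated value is 9000 nM, with an expected range of 800 nM to 40000 nM.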

Compound 4, half-maximal inhibitory concentration: 18400 nM
Compound 4: middle estimate off by 2.0-fold (0.31 log units), on the low side; low and high end bracket the measured number.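

In this assay, for the compounds shown here, this is the first direct test of the amide-type nitrogen in the ring: 4-methoxyphenyl in place of hydrogen gives a 1.4-fold lower number from compound 1 to compound 4 (0.16 log units; within the scatter). The nitrogen of the shared core can therefore carry a group of 8 heavy atoms, including a six-membered aromatic ring, with no readable difference from the hydrogen of compound 1, so this change does not separate the two compounds in this assay. Compound 4 also yields an actual number, whereas compound 2 and compound 3 remain limits and not numbers: the limit of > 40000 nM in this assay, at which 2 of the 4 values shown sit.

Going by these compounds, whether any other group on this nitrogen, such as methyl, a longer alkyl chain, or a chain ending in an amine or a carboxylic acid, would give a step beyond the scatter remains open. Also open, on these data alone, is what a plain phenyl on the same nitrogen would give against 4-methoxyphenyl, which would show whether the methoxy on that ring has any part in the number.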